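From Fluorine to Chlorine on One Aromatic Ring

The source may report more compounds than this note shows. Statements on the series, on what has been measured and on what is new or still open speak of the compounds shown alone.

Compound 2 `COC(=O)c1c(Nc2ccc(F)cc2)sc(C(=O)c2ccc(OC)cc2)c1C` was tested in a functional assay, with a stated time of 150 min, tested at 15 ug/mL (a higher number here means a stronger effect of the compound at the concentration tested, a lower number a weaker effect), and gives 15.2%. Among the compounds with values here, its only measured companion is compound 1 `COC(=O)c1c(Nc2ccc(OC)cc2)sc(C(=O)c2ccc(OC)cc2)c1C`, which in this assay gives 7.8%; the change between them, fluoro in place of methoxy on an aromatic carbon, brought a number 7.4 percentage points higher from compound 1 to compound 2 (within the scatter), so these two numbers cannot be told apart. Compound 3 `COC(=O)c1c(Nc2ccc(Cl)cc2)sc(C(=O)c2ccc(OC)cc2)c1C` has not yet been measured. Compared with compound 2 it carries chloro in place of fluoro on an aromatic carbon. Within the data shown here, no measured step swaps one halogen for another, and the single step known, from compound 1 to compound 2, stayed within the scatter with a different swap at the same place; the change to compound 3 is therefore expected to give no step beyond the scatter in this assay. The expected step is a number 0.8 percentage points higher from compound 2 to compound 3 (within the scatter). Compound 3 is estimated to give 16%, within a range from 5% to 30%.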

Compound 3, a percentage reported as activity, at one concentration (the size of the read-out at that concentration, not a potency): "not active" (no number reported)
Compound 3: no number reported, and the estimate cannot be compared.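

In this assay, within the data shown here, compound 3 is reported as "not active" without a number, so no step from compound 2 to compound 3 can be read. No other data bear on this result. Compounds 2 and 3 leave open how far chloro and fluoro differ at this place on the ring.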